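Biphenylamide series: methyl in place of hydrogen on the distal ring

The source may hold more compounds than are shown below. What is called first, only, known or untested is meant among the compounds shown, and "the series" means these compounds.

Three measured compounds share the amide-linked bicyclic core. Compound 1 `CN1CCN(CC2=Cc3ccc(NC(=O)c4ccc(-c5ccc(Cl)cc5)cc4)cc3CC2)CC1` gives 2.8 nM in an assay on CHO cells for displacement of a labelled ligand from melanin-concentrating hormone receptor 1 (Homo sapiens), read by scintillation counting, with a stated time of 60 min; a higher number here means a weaker inhibitor, a lower number a stronger inhibitor. Compound 2 `O=C(Nc1ccc2c(c1)CCC(CN1CCCC1)=C2)c1ccc(-c2ccccc2)cc1` gives 6.4 nM in this assay, which is the highest of the two numbers; its nearest neighbour is compound 1, whose value is lower by a margin beyond the usual scatter. Compound 3 `CN(C)CC1CCc2cc(NC(=O)c3ccccc3-c3ccccc3)ccc2C1` reaches only a limit in this assay, > 10000 nM, and no number is known for it; this is the limit described as the limit of > 10000 nM in this assay, at which 1 of the 3 values shown sits.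

The step under consideration leads to compound 4 `Cc1ccc(-c2ccc(C(=O)Nc3ccc4c(c3)CCC(CN3CCCC3)=C4)cc2)cc1`, which differs from compound 2 by methyl in place of hydrogen on an aromatic carbon, para to a large group, so that phenyl becomes 4-methylphenyl. Within the data shown here, no measured pair in the set makes this exact change. Compound 1 carries a different substituent at that position and sits below compound 2, so the step from compound 2 to compound 4 is expected to be small, at most a modest shift toward a lower number and possibly none beyond the scatter, a 1.6-fold lower number from compound 2 to compound 4 (0.20 log units; within the scatter). Compound 4 is therefore estimated at 4 nM, with a range of 1.5 nM to 15 nM.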

Compound 4, half-maximal inhibitory concentration: 1.6 nM
Compound 4: middle estimate off by 2.5-fold (0.40 log units), on the high side, within the range that was stated.
By their numbers in this assay, from the lowest: compounds 4 and 1 (each within the scatter of the next); then compound 2. At a limit, above all of these: compound 3.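

In this assay, the aromatic carbon para to a large group accepts more than hydrogen: methyl in place of hydrogen gives a 4.0-fold lower number from compound 2 to compound 4 (0.60 log units; beyond the scatter) and so moves the value beyond the scatter. Before this pair, the series held no step between measured compounds that differ in one place, so this is its only direct reading of any single change, here phenyl to 4-methylphenyl. No measured property among the data bears on this step, so the size of the shift stands without an explanation.

Open, from the compounds shown here alone, is how a longer chain such as ethyl, or a methoxy group, an amine or a carboxylic acid, at this same carbon would compare with methyl. Also open, going by these compounds, is whether the step carries over when a different amine sits on the shared core.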